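From Nitrophenyl to Methoxyphenyl: A Cytotoxicity Question

A few compounds are considered here, and "the series" means these few. Any claim that something is new, unique, unknown or untested is made for them only; others in the source may bear on it.

Three related compounds have been tested so far in an ADME assay on MT4 cells (Homo sapiens) for cytotoxicity, read by MTT assay, with a stated time of 3 days (on this read-out higher numbers stand for lower toxicity in this test and lower numbers for higher toxicity in this test), for the harm they do to cells. Compound 1 (`O=C(COC(=O)c1ccc([N+](=O)[O-])o1)NC1CCc2ccccc21`) gives > 100000 nM as its entry, which is a limit of the assay and not a number. Compound 2 (`CC(C)(C)N(CCCc1ccccc1)C(=O)COC(=O)c1ccc([N+](=O)[O-])o1`) is recorded as "not active" (no number reported) with no number attached. Compound 3 (`CC(C)(C)N(Cc1cccc([N+](=O)[O-])c1)C(=O)COC(=O)c1ccc([N+](=O)[O-])o1`) gives > 100000 nM as its entry, and this too is only a limit. For the measured compounds named here, compound 3 therefore has no exact position and stands at the limit of > 100000 nM in this assay, at which 2 of the 3 values shown sit, with no measured step linking it to another compound.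

The next compound, compound 4 (`COc1ccc(CN(C(=O)COC(=O)c2ccc([N+](=O)[O-])o2)C(C)(C)C)cc1`), differs from compound 3 in one place: 4-methoxyphenyl in place of 3-nitrophenyl on a saturated chain carbon bound to an amide-type nitrogen In words, this is 4-methoxyphenyl in place of 3-nitrophenyl on a saturated chain carbon bound to an amide-type nitrogen. Going by the values given here, no measured step shows what such a swap does in this assay so the expectation is for no shift beyond the usual scatter, in either direction. This expectation rests only on the limit of compound 3 at > 100000 nM and on nothing finer. The expected change is a number no higher from compound 3 to compound 4 (the limit leaves the size open) as an estimate. For compound 4 the estimated value is 100000 nM with an expected range from 30000 nM to 200000 nM and a limit in place of a number is likely.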

Compound 4, half-maximal cytotoxic concentration: > 100000 nM
Compound 4: only a limit was reported; the forecaster's own chance of this, stated with the estimate: 75%; the middle value sits exactly at the limit.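

Compound 3 and compound 4 give no readable step in this assay, because each is recorded only as a limit of the assay and not as a number: the limit of > 100000 nM in this assay, at which 3 of the 4 values shown sit.

The compounds shown leave open at what concentration, if any, they harm these cells, and so whether 4-methoxyphenyl in place of 3-nitrophenyl makes any difference.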